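The source may hold more compounds than are shown below. What is called first, only, known or untested is meant among the compounds shown, and "the series" means these compounds.

Measured so far:
- compound 1 `O=C(N/N=C/c1ccc(F)cc1)c1cn(C2CC2)c2cc(N3CCNCC3)c(F)cc2c1=O`: 25000 nM
- compound 2 `O=C(N/N=C/c1ccc([N+](=O)[O-])cc1)c1cn(C2CC2)c2cc(N3CCNCC3)c(F)cc2c1=O`: 25000 nM
- compound 3 `O=C(N/N=C/c1ccccc1O)c1cn(C2CC2)c2cc(N3CCNCC3)c(F)cc2c1=O`: 25000 nM

In a functional assay on HL-60 cells (Homo sapiens) for cytotoxicity, read by MTT assay (on this read-out higher numbers stand for weaker inhibition and lower numbers for stronger inhibition), compound 2 gives 25000 nM, level with the other two compounds. Next is compound 4 `COc1ccc(/C=N/NC(=O)c2cn(C3CC3)c3cc(N4CCNCC4)c(F)cc3c2=O)cc1`, with the change methoxy in place of nitro on an aromatic carbon, para to a large group. Among the measured compounds shown here, three measured steps bear on this. Nitro in place of fluoro at this same carbon gives no change at the digits printed from compound 1 to compound 2 (within the scatter). The changes to 2-hydroxyphenyl give no change at the digits printed from compound 1 to compound 3 (within the scatter) and no change at the digits printed from compound 2 to compound 3 (within the scatter). None of these exceeds the scatter, so no step beyond the scatter is expected in this assay. The expected result is no change at the digits printed from compound 2 to compound 4 (within the scatter). For compound 4 the estimate is 25000 nM, with an expected range of 14000 nM to 40000 nM.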

Compound 4, half-maximal inhibitory concentration: 25000 nM
Estimate against measurement, compound 4: no gap at the digits printed; measured number inside the range.
By their numbers in this assay, from the lowest: compounds 1, 2, 3 and 4 (each within the scatter of the next).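

Methoxy in place of nitro gives no change at the digits printed from compound 2 to compound 4 (within the scatter) in this assay and methoxy in place of fluoro gives no change at the digits printed from compound 1 to compound 4 (within the scatter) on this same aromatic carbon. 4-Methoxyphenyl in place of 2-hydroxyphenyl gives no change at the digits printed from compound 3 to compound 4 (within the scatter) as well, so an oxygen-linked alkyl group here also leaves the reading flat across these four compounds. No measurement on hand accounts for this flat reading.

Still open, from the compounds shown here alone, is whether an amine or a carboxylic acid on this carbon would give a step beyond the scatter. Also open, going by these compounds, is whether a change to the shared core would move the number when this aromatic ring stays fixed.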